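This account rests on a few compounds, and the source may have more. Where it says the series, first, only, none or still open, it means among the compounds named here.

Measured compounds:
Compound 1, `O=C(N/N=C/c1ccccc1)c1cccnc1Nc1cccc(C(F)(F)F)c1`, gives 53.9% in a functional assay on the whole organism (strain Wistar) for inhibition, with Rattus norvegicus as the target, read by paw edema, with a stated time of 1 h, at a dose of 10 mg/kg by the intraperitoneal route; a lower number here means less inhibition, a higher number more inhibition at the dose given (going by the name of the read-out).
Compound 2, `O=C(N/N=C/c1cccnc1)c1cccnc1Nc1cccc(C(F)(F)F)c1`, gives 76.1% in this assay.
Compound 3, `CNc1ncccc1C(=O)N/N=C/c1ccccc1`, gives 67.6% in this assay.

The one counted step among these three runs from compound 1 to compound 2, where the change is pyridin-3-yl in place of phenyl on a carbon with a double bond to nitrogen. In this assay this gave a number 22.2 percentage points higher from compound 1 to compound 2 (beyond the scatter). Compound 3 carries a different core from compound 1; the difference between the two cores is not broken down here. Compound 3 stands second of the three numbers: its value and that of compound 2 lie within the scatter of each other, while compound 1 is lower by a margin beyond the scatter.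

The unmeasured compound 4, `CNc1ncccc1C(=O)N/N=C/c1cccnc1`, is related to compound 3 by pyridin-3-yl in place of phenyl on a carbon with a double bond to nitrogen. For the measured compounds named here, this is the same change as the one from compound 1 to compound 2, made at the same kind of place on the core of compound 3 rather than that of compound 1. Because the step of a number 22.2 percentage points higher from compound 1 to compound 2 (beyond the scatter) was measured on the other core, compound 4 is expected to move in the same direction, though since compound 3 already starts from a higher number than compound 1 did, the step is estimated somewhat smaller, at a number 15.4 percentage points higher from compound 3 to compound 4 (beyond the scatter). Compound 4 is therefore estimated to give 83% in this assay, with a range from 68% to 95%.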

Compound 4, a percentage reported as inhibition, in the whole organism at one dose (the size of the read-out at that dose, not a potency): 61.1%
For compound 4 the middle estimate is 21.9 percentage points above the measured one; measured number outside the range, below it.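

On the core of compound 3, pyridin-3-yl in place of phenyl on a carbon with a double bond to nitrogen gave a number 6.5 percentage points lower from compound 3 to compound 4 (within the scatter) in this assay. For the compounds shown here, the step measured on the core of compound 1 therefore did not carry over at the same size to the core of compound 3: the same change on two cores in this assay, a number 22.2 percentage points higher (beyond the scatter) from compound 1 to compound 2 and a number 6.5 percentage points lower (within the scatter) from compound 3 to compound 4, 28.7 percentage points apart, beyond the scatter of two such steps This shows that, in this small set, the outcome of the change depends on the core that carries it, but with only two pairs it does not show what in the two cores sets the steps apart, how the change would behave on any further core, or how the compounds compare in potency, as each number is a reading at a single dose.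

The compounds shown leave open whether other groups on that same carbon, such as pyridin-2-yl, a thiophene or a carboxylic acid, would follow the step seen on one core, the other, or neither. They also leave open how the change would behave on a core with a different amine, such as a morpholine or a longer chain like butylamine, and so whether the two steps are the ends of a wider range.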